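The source may hold more compounds than are shown below. What is called first, only, known or untested is meant among the compounds shown, and "the series" means these compounds.

Three compounds of this series share one core and differ only in the group on a nitrogen on an aromatic ring. Compound 1 `CC(C)c1ccc(-c2nc(SCc3cn(CC(=O)NC(=O)Nc4ccccn4)nn3)nc(Nc3ccc(Cl)cc3)c2C#N)cc1` carries a 4-chlorophenyl there. In a functional assay on MGC-803 cells (Homo sapiens) for inhibition, read by MTT assay, with a stated time of 72 h (on this read-out higher numbers stand for weaker inhibition and lower numbers for stronger inhibition), compound 1 gives only a limit, > 64000 nM. Compound 2 `CC(C)c1ccc(-c2nc(SCc3cn(CC(=O)NC(=O)Nc4ccccn4)nn3)nc(Nc3cccc(Cl)c3)c2C#N)cc1` carries a 3-chlorophenyl. In this assay compound 2 likewise gives a limit, > 64000 nM. Compound 3 `COc1ccc(Nc2nc(SCc3cn(CC(=O)NC(=O)Nc4ccccn4)nn3)nc(-c3ccc(C(C)C)cc3)c2C#N)cc1` carries a 4-methoxyphenyl. In this assay compound 3 too gives a limit, > 64000 nM. The steps a step that the two limits leave unreadable from compound 1 to compound 2, a step that the two limits leave unreadable from compound 1 to compound 3 and a step that the two limits leave unreadable from compound 2 to compound 3 cannot be sized because of the limit of > 64000 nM in this assay, at which 3 of the 3 values shown sit. Compound 3 therefore stands where the other two stand, at a limit and not at a number. Compound 4 `CC(C)c1ccc(Nc2nc(SCc3cn(CC(=O)NC(=O)Nc4ccccn4)nn3)nc(-c3ccc(C(C)C)cc3)c2C#N)cc1` differs from compound 3 in one place: isopropyl in place of methoxy on an aromatic carbon. Going by the values given here, none of the measured steps gives a readable size that bears on this change; all three remain unreadable. Compound 4 is therefore expected to remain at the same limit, with a step that the limit leaves unreadable from compound 3 to compound 4 that cannot be told apart from no change. The estimate for compound 4 in this assay is 100000 nM, between 40000 nM and 300000 nM.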

Compound 4, half-maximal inhibitory concentration: 15800 nM
The estimate for compound 4 lay 6.3-fold (0.80 log units) above the measured number; the whole stated range lies above it.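

In this assay, this position proves able to shift the read-out: isopropyl in place of methoxy gives an at least 4.0-fold lower number from compound 3 to compound 4 (0.60 log units; beyond the scatter), while the comparisons with the two chlorinated compounds give an at least 4.0-fold lower number from compound 2 to compound 4 (0.60 log units; beyond the scatter) and an at least 4.0-fold lower number from compound 1 to compound 4 (0.60 log units; beyond the scatter). Among the four compounds shown, only compound 4, with its 4-isopropylphenyl on the nitrogen, gives a number, whereas compound 1, compound 2 and compound 3 all remain at a limit. Each of these steps is only a minimum size because one compound in each pair has no exact value: the limit of > 64000 nM in this assay, at which 3 of the 4 values shown sit.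

As far as these compounds go, the steps among compound 1, compound 2 and compound 3 still cannot be read, so the true size of each step with compound 4 stays open. The compounds shown also leave open whether a tert-butyl or n-propyl group on that aromatic carbon would match compound 4.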